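The compounds below may be only part of what the source reports. "The series", "measured", "known", "first", "only" and "open" are said of these compounds alone.

In a functional assay on the whole organism for inhibition, with Rattus norvegicus as the target, with a stated time of 30 min, at a dose of 1 mg/kg by the intravenous route (a lower number here means less inhibition, a higher number more inhibition at the dose given (going by the name of the read-out)), compound 3 `O=C(Nc1nc[nH]n1)c1cc(=O)c2ccccc2o1` gives 0%. Compound 2 `O=C(O)CCCNC(=O)c1cc(=O)c2ccccc2o1` gives 0%; the two stand level, together the lowest of the three numbers, and no change at the digits printed from compound 2 to compound 3 (within the scatter). Compound 1 `O=C(Nc1nnn[nH]1)c1cc(=O)c2ccccc2o1` gives 100%, so that a number 100 percentage points lower from compound 1 to compound 3 (beyond the scatter) and a number 100 percentage points lower from compound 1 to compound 2 (beyond the scatter). Compound 4 `Cn1nnc(NC(=O)c2cc(=O)c3ccccc3o2)n1` differs from compound 3 by 2-methyl-2H-tetrazol-5-yl in place of 1H-1,2,4-triazol-3-yl on an amide-type nitrogen. Among the compounds with values here, the step from compound 1 to compound 3 bears on it most, as both exchange one five-membered ring on the amide nitrogen for another, but it runs the other way, and no measured step covers a ring with no hydrogen-bond donor. The expected change in this assay is therefore a number 25 percentage points higher from compound 3 to compound 4 (beyond the scatter), with wide uncertainty. Compound 4 is estimated at 25%, between 0% and 75%.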

Compound 4, a percentage reported as inhibition, in the whole organism at one dose (the size of the read-out at that dose, not a potency): 25%
Compound 4: the middle estimate sits on the measured number at the digits printed; the range from low to high includes it.
By their numbers in this assay, from the lowest: compounds 2 and 3 (each within the scatter of the next); then compound 4; then compound 1.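

In this assay, 2-methyl-2H-tetrazol-5-yl on the amide-type nitrogen gives a measurable read-out with 0 hydrogen-bond donors in the group: a number 25 percentage points higher from compound 3 to compound 4 (beyond the scatter) and a number 25 percentage points higher from compound 2 to compound 4 (beyond the scatter). It still falls short of the 1H-tetrazol-5-yl group, with a number 75 percentage points lower from compound 1 to compound 4 (beyond the scatter), so this position distinguishes between the two tetrazole groups. No measured evidence accounts for these steps. Going by these compounds, how 1-methyl-1H-tetrazol-5-yl would compare remains open. So does the effect of a longer chain, such as 2-ethyl-2H-tetrazol-5-yl, on the same ring.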